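The compounds below may be only part of what the source reports. "The series", "measured", "known", "first", "only" and "open" are said of these compounds alone.

Two measured compounds frame this account. Compound 1 `O=C(N[C@@H]1CNCC[C@H]1c1ccc(Cl)cc1)c1ccc(-c2ncnc3c2CCC3O)s1` gives 24100 nM in a functional assay on OVCAR-8 cells (Homo sapiens) for antiproliferative activity (a lower number here means a stronger inhibitor, a higher number a weaker inhibitor), while compound 2 `Cn1ncc(Cl)c1-c1cc(C(=O)N[C@@H]2CN[C@H](CC(=O)O)C[C@H]2c2ccc(Cl)c(Cl)c2)oc1Cl` gives 5120 nM, the lower of the two numbers, with compound 1 standing beyond the scatter above it. Compound 3 `Cn1ncc(Cl)c1-c1cc(C(=O)N[C@@H]2CN[C@H](CC(=O)NCC(O)CO)C[C@H]2c2ccc(Cl)c(Cl)c2)oc1Cl` has not been measured. It differs from compound 2 by (2,3-dihydroxypropyl)amino in place of hydroxy on a carbonyl carbon. Within the data shown here, no measured pair shows a step of this kind, so its size is uncertain; a step from compound 2 to compound 3 of modest size, a 1.3-fold higher number from compound 2 to compound 3 (0.10 log units; within the scatter), is expected, which may fall within the scatter. For compound 3 the estimate is 6500 nM, with a range from 2000 nM to 20000 nM.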

Compound 3, half-maximal inhibitory concentration: 5900 nM
The estimate for compound 3 lay 1.1-fold (0.04 log units) above the measured number; the measured number falls inside the stated range.
By their numbers in this assay, from the lowest: compounds 2 and 3 (each within the scatter of the next); then compound 1.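

In this assay, (2,3-dihydroxypropyl)amino in place of hydroxy on a carbonyl carbon gives a 1.2-fold higher number from compound 2 to compound 3 (0.06 log units; within the scatter), the first single-place step readable in this series. At this carbonyl carbon, whose other neighbour is a saturated chain carbon, the number therefore does not depend on keeping the hydroxy. Nothing available explains this result.

From the compounds shown here alone, whether methylamino, methoxy or a longer chain carrying a terminal amine at this carbonyl carbon would read the same remains open. So does whether any group here could shift the number beyond the scatter.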